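A few compounds are considered here, and "the series" means these few. Any claim that something is new, unique, unknown or untested is made for them only; others in the source may bear on it.

Compound 1 `COc1cc2c(cc1O)CCC(C)(CC(=O)O)O2` gives 32300 nM in a functional assay on SH-SY5Y cells (Homo sapiens) for inhibition, read by fluorescence, with a stated time of 1 h; on this read-out higher numbers stand for weaker inhibition and lower numbers for stronger inhibition. Compound 2 `COc1cc2c(cc1O)CCC(C)(CC(=O)N[C@@H](C)C(=O)O)O2` gives 92600 nM in this assay. Compound 3 `COc1cc2c(cc1O)CCC(C)(CCNC(=O)/C=C(C)/C=C/C=C(C)/C=C/C1=C(C)CCCC1(C)C)O2` reaches only the limit of > 300000 nM in this assay.

Compound 1 holds the lowest of the two numbers; its nearest neighbour is compound 2, reached by a 2.9-fold higher number from compound 1 to compound 2 (0.46 log units; beyond the scatter), which turns the carboxylic acid into an amide. Compound 4 `COc1cc2c(cc1O)CCC(C)(CCNC(C)=O)O2` differs from compound 1 by acetamidomethyl in place of carboxy on a saturated chain carbon bound to a saturated ring carbon. The step to compound 2 is the one that bears on this change, since it too converts the acid end into an amide; compound 3 carries an amide on a much longer chain and sits at the limit of > 300000 nM in this assay, at which 1 of the 3 values shown sits. A modest weakening is therefore expected, a 2.0-fold higher number from compound 1 to compound 4 (0.30 log units; within the scatter). Compound 4 is estimated at 65000 nM, between 20000 nM and 220000 nM.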

Compound 4, half-maximal inhibitory concentration: 50300 nM
Compound 4: the middle estimate sits 1.3-fold (0.11 log units) above what was measured, within the range that was stated.
By their numbers in this assay, from the lowest: compounds 1, 4 and 2 (each within the scatter of the next, the first and the last beyond it). At a limit, above all of these: compound 3.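

In this assay, replacing carboxy with acetamidomethyl gives a 1.6-fold higher number from compound 1 to compound 4 (0.19 log units; within the scatter), so compounds with and without the acid at this chain end cannot be told apart here. The acid is therefore not required for a measurable number on this read-out, which compounds 1 and 2, both acids, could not show. Compound 3 also has an amide but a much longer acyl chain, and its value is a limit: the limit of > 300000 nM in this assay, at which 1 of the 4 values shown sits.

From the compounds shown here alone, it remains open how a free primary amine would read on this chain. Acyl chains of intermediate length, between acetyl and the long chain of compound 3, are also unresolved.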